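Changing the Amide Substituent: From Compound 3 to Compound 4

A few compounds are considered here, and "the series" means these few. Any claim that something is new, unique, unknown or untested is made for them only; others in the source may bear on it.

Compound 1 `CC(=O)Nc1c(C(O)(C(F)(F)F)C(F)(F)F)ccc2ccccc12` gives 87% in a functional assay (Sus scrofa) with sulfonylurea receptors; K-ATP channels (Homo sapiens) as the target; a higher number here means a larger maximal response, a lower number a smaller maximal response.
Compound 2 `CC(C)=CC(=O)Nc1c(C(O)(C(F)(F)F)C(F)(F)F)ccc2ccccc12` gives 96% in this assay.
Compound 3 `COCC(=O)Nc1c(C(O)(C(F)(F)F)C(F)(F)F)ccc2ccccc12` gives 93% in this assay.

The three measured compounds share one core and differ only in the group on the amide carbonyl carbon. Their numbers in this assay sit close together: the step of a number 9 percentage points higher from compound 1 to compound 2 (within the scatter) is within the scatter, as is a number 6 percentage points higher from compound 1 to compound 3 (within the scatter) and a number 3 percentage points lower from compound 2 to compound 3 (within the scatter). Compound 3 has the second highest of the three numbers, but its gap to compound 2 and its gap to compound 1 are both within the usual scatter, so the three are best read as one level.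

Compound 4 `O=C(Nc1c(C(O)(C(F)(F)F)C(F)(F)F)ccc2ccccc12)c1cccc([N+](=O)[O-])c1` is the next compound, not yet measured. It differs from compound 3 in one place: 3-nitrophenyl in place of methoxymethyl on a carbonyl carbon. For the measured compounds named here, none of the measured steps involve an aromatic group at this position, so the three steps bear on the change only in that every variation at the carbonyl carbon so far stayed within the scatter. On that basis no step beyond the scatter is expected in this assay. Compound 4 is therefore estimated to give 92%, within a range from 78% to 102%. The expected step of a number 1 percentage points lower from compound 3 to compound 4 (within the scatter) is estimated to lie within the scatter.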

Compound 4, largest response reached (reported as efficacy), in percent of the reference or control that the assay uses: 99%
Estimate against measurement, compound 4: 7 percentage points below; the measured number falls inside the stated range.
By their numbers in this assay, from the lowest: compounds 1, 3, 2 and 4 (each within the scatter of the next, the first and the last beyond it).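

For the compounds shown here, an aromatic ring can sit on the carbonyl carbon without leaving the level set by the earlier compounds: in this assay, 3-nitrophenyl, with its 9 heavy atoms against the 3 of methoxymethyl, gives a number 6 percentage points higher from compound 3 to compound 4 (within the scatter) and, against 2-methylprop-1-en-1-yl, a number 3 percentage points higher from compound 2 to compound 4 (within the scatter) as the comparison. The series also now holds its first step beyond the scatter, a number 12 percentage points higher from compound 1 to compound 4 (beyond the scatter) when 3-nitrophenyl replaces methyl, and it is a modest one that compound 2 and compound 3 do not separate from their neighbours. Nothing measured here accounts for these steps.

With a single aromatic group at this place, the shown compounds cannot tell whether the ring alone or the nitro group on it goes with the modest step over compound 1, and a plain phenyl, or a phenyl carrying an amine or a carboxylic acid instead of the nitro group, would separate the two. Going by these compounds, how a saturated ring such as cyclohexyl or a longer alkyl chain on the carbonyl carbon would read in this assay also stays open.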